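Series notes: ring swap on the aromatic nitrogen of compound 1

A few compounds are considered here, and "the series" means these few. Any claim that something is new, unique, unknown or untested is made for them only; others in the source may bear on it.

Compound 1 `COc1ccc(-c2c(-c3ccc(OC)cc3)n(Cc3ccccc3)c3ncn([C@@H]4CCCC[C@H]4O)c(=N)c23)cc1` is the reference for this step. Among the measured compounds shown here, in an ADME assay on microsomes from liver (Mus musculus, strain CD1) for metabolic stability, read by LC-MS, using NADPH, with a stated time of 60 min (on this read-out lower numbers stand for a shorter-lived compound and higher numbers for a longer-lived compound), compound 1 gives 0.487 h, the highest of the three numbers so far. Compound 2 `N=c1c2c(-c3ccccc3)c(-c3ccccc3)n(Cc3ccccc3)c2ncn1CCCN1CCN(c2ccccc2)CC1` gives 0.233 h in this assay, a lower number that lies beyond the scatter. Compound 3 `COc1ccc(Cn2c(-c3ccccc3)c(-c3ccccc3)c3c(=N)n(CC4CCOCC4)cnc32)cc1` gives 0.217 h in this assay, also lower than compound 1 and likewise beyond the scatter; compound 2 and compound 3 sit within the scatter of each other, so no order between them is claimed.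

Compound 4 `COc1ccc(-c2c(-c3ccc(OC)cc3)n(Cc3ccccc3)c3ncn(C4CCOCC4)c(=N)c23)cc1` carries the shared core of compound 1 with one change: oxan-4-yl in place of 2-hydroxycyclohexyl on an aromatic nitrogen. For the measured compounds named here, none of the three measured compounds differs from another in one place, so no measured step bears on this change, and the expectation rests on the values alone.

Going by the values given here, for compound 4 a small downward step is expected in this assay, a 1.4-fold lower number from compound 1 to compound 4 (0.14 log units; within the scatter), because compound 1 holds the longest-lived value 0.487 h and the two other compounds lie lower, yet with no measured step of this kind the move is expected to stay within the scatter. Compound 4 is estimated at 0.35 h in this assay, with a range from 0.15 h to 0.8 h.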

Compound 4, half-life: 0.978 h
Beside the measured number, compound 4's estimate is 2.8-fold (0.45 log units) below it; the whole stated range lies below it.
By their numbers in this assay, from the lowest: compounds 3 and 2 (each within the scatter of the next); then compounds 1 and 4 (each within the scatter of the next).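

Notes on the aromatic nitrogen: in this assay, the exchange of 2-hydroxycyclohexyl for oxan-4-yl gives the first step that can be read at this position, a 2.0-fold higher number from compound 1 to compound 4 (0.30 log units; within the scatter), on the otherwise unchanged shared core. The entering ring has 0 hydrogen-bond donors and no defined stereocentres, whereas the leaving group has 1 hydrogen-bond donor and 2 defined stereocentres, so for this one pair the half-life stays within the scatter without the donor or the stereocentres of compound 1, and the pair supports no claim of a gain. No supporting measurement bears on the reason for this outcome.

With a single step at this position, the separate contributions of the ring oxygen and the hydroxyl group remain unresolved, and unsubstituted cyclohexyl on this aromatic nitrogen would be the direct test of both. Also open, as far as these compounds go, is whether a carboxylic acid or an open 2-hydroxyethyl chain at the same place would carry the half-life beyond the scatter in either direction on this core.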